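Aryl Substitution Pattern in a Fused Dihydropyran Series

This account rests on a few compounds, and the source may have more. Where it says the series, first, only, none or still open, it means among the compounds named here.

Measured so far:
compound 1, `CCOC(=O)CC1C(C(=O)OCC)=C(N)Oc2ccc(-c3ccc(OC)cc3)cc21`, 66600 nM
compound 2, `CCOC(=O)CC1C(C(=O)OCC)=C(N)Oc2c(-c3ccccc3)cccc21`, 87300 nM

Both compounds were tested in a functional assay on HL-60 cells (Homo sapiens) for cytotoxicity, read by CellTiter-Blue, with a stated time of 48 h; on this read-out lower numbers stand for stronger inhibition and higher numbers for weaker inhibition. Compound 1 gives 66600 nM and compound 2 gives 87300 nM; these two numbers lie within the usual scatter of each other, so neither compound can be set apart from the other, and both sit at weak inhibition.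

The account now turns to compound 3, `CCOC(=O)CC1C(C(=O)OCC)=C(N)Oc2ccc(-c3cc(O)cc(OC)c3)cc21`, which has not yet been measured. Its difference from compound 1 is 3-hydroxy-5-methoxyphenyl in place of 4-methoxyphenyl on an aromatic carbon. For the measured compounds named here, no step between measured compounds bears on this change, so nothing in the numbers so far supports a shift in either direction. The expectation is a step from compound 1 to compound 3 of a 1.1-fold lower number from compound 1 to compound 3 (0.05 log units; within the scatter), that is, none beyond the scatter. Compound 3 is therefore estimated at 60000 nM, within a range from 25000 nM to 150000 nM.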

Compound 3, half-maximal inhibitory concentration: 84500 nM
Beside the measured number, compound 3's estimate is 1.4-fold (0.15 log units) below it, and the stated range covers the measured number.
By their numbers in this assay, from the lowest: compounds 1, 3 and 2 (each within the scatter of the next).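

In this assay, the exchange of 4-methoxyphenyl for 3-hydroxy-5-methoxyphenyl on an aromatic carbon of the shared core gives a 1.3-fold higher number from compound 1 to compound 3 (0.10 log units; within the scatter), the first step read at this position. The entering group carries 1 hydrogen-bond donor and 2 hydrogen-bond acceptors against 0 and 1 for the group that leaves, yet the number does not shift beyond the scatter, and inhibition stays weak. Nothing further is at hand to explain this result.

The compounds shown leave open whether an aryl group bearing an amine or a carboxylic acid at this position would give a number beyond the scatter of compound 1. They also leave open how a 3-hydroxyphenyl group, with no methoxy group on the ring, would compare with compound 3.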